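Thiophen-3-yl for phenyl on the shared core

This account rests on a few compounds, and the source may have more. Where it says the series, first, only, none or still open, it means among the compounds named here.

Measured so far in an ADME assay on MRC5 cells (Homo sapiens), read by MTT assay, with a stated time of 72 h; a higher number here means a weaker inhibitor, a lower number a stronger inhibitor:
compound 1 `COc1nc(N)nc2c1c(-c1ccccc1)cn2[C@@H]1O[C@H](CO)[C@@H](O)[C@H]1O`, a limit: > 100000 nM
compound 2 `Nc1nc(N)c2c(-c3ccccc3)cn([C@@H]3O[C@H](CO)[C@@H](O)[C@H]3O)c2n1`, a limit: > 100000 nM
compound 3 `Cc1nc(N)c2c(-c3cccs3)cn([C@@H]3O[C@H](CO)[C@@H](O)[C@H]3O)c2n1`, a limit: > 100000 nM

Compound 1 stands at the limit of this assay, not at a number; compound 2 and compound 3 stand at the same limit. Going by the values given here, the only step among measured compounds that differ in one place, a step that the two limits leave unreadable from compound 1 to compound 2, is amino in place of methoxy on an aromatic carbon, and its size cannot be read, since both ends are limits (the limit of > 100000 nM in this assay, at which 3 of the 3 values shown sit).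

Compound 4 `COc1nc(N)nc2c1c(-c1ccsc1)cn2[C@@H]1O[C@H](CO)[C@@H](O)[C@H]1O` is the unmeasured compound. It differs from compound 1 by thiophen-3-yl in place of phenyl on an aromatic carbon. Among the compounds with values here, no measured step bears directly on a change at the aromatic carbon that carries the phenyl; compound 3, which carries a thiophen-2-yl there, sits at the limit like the others. With every value shown at the limit, no step beyond the scatter is expected in this assay; the estimated step that the limit leaves unreadable from compound 1 to compound 4 is taken as none. Compound 4 is therefore expected to give about 150000 nM, within 50000 nM to 500000 nM, most likely reported only as a limit.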

Compound 4, half-maximal inhibitory concentration: > 100000 nM
Compound 4: a limit, no number; the forecaster's own chance of this, stated with the estimate: 85%; the middle value is on the limit's open side.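

No size can be read for thiophen-3-yl in place of phenyl between compound 1 and compound 4, since both stand at a limit: the limit of > 100000 nM in this assay, at which 4 of the 4 values shown sit.

The compounds shown leave open whether any change on the shared core would give a number rather than a limit.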